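A few compounds are considered here, and "the series" means these few. Any claim that something is new, unique, unknown or untested is made for them only; others in the source may bear on it.

Measured so far in this study:
Compound 1 `O=C(N[C@H]1CC[C@H](C(=O)O)CC1)[C@H](C1CCCCC1)n1c(-c2ccc(Cl)nc2)nc2cc(F)c(F)cc21`: 1700 nM
Compound 2 `COc1ccc(-c2nc3cc(F)c(F)cc3n2[C@H](C(=O)N[C@H]2CC[C@H](C(=O)O)CC2)C2CCCCC2)c(Cl)n1`: 290 nM
Compound 3 `O=C(O)Cc1ccc(NC(=O)C(C2CCCCC2)n2c(-c3ccc(Cl)cc3)nc3cc(F)c(F)cc32)cc1`: 1400 nM

In an assay on isolated protein for displacement of a labelled ligand from Bile acid receptor (Homo sapiens), read by scintillation proximity assay and radioligand binding (a lower number here means a stronger inhibitor, a higher number a weaker inhibitor), compound 1 gives the highest of the three numbers; compound 3 gives 1400 nM, within the scatter of compound 1, while compound 2 lies well apart. For the measured compounds named here, the single measured step between close neighbours, a 5.9-fold lower number from compound 1 to compound 2 (0.77 log units; beyond the scatter), alters the group on an aromatic carbon and says nothing about the acid end of the molecule. Compound 4 `O=C(O)CO[C@H]1CC[C@H](NC(=O)[C@H](C2CCCCC2)n2c(-c3ccc(Cl)nc3)nc3cc(F)c(F)cc32)CC1` instead carries carboxymethoxy in place of carboxy on a saturated ring carbon. Going by the values given here, the only comparison touching the acid end is compound 3 against compound 1, whose numbers lie within the scatter of each other. Among the compounds with values here, with no measured step bearing on this change, compound 4 is expected to show a 1.1-fold lower number from compound 1 to compound 4 (0.05 log units; within the scatter), that is, nothing beyond the scatter. The estimate for compound 4 is 1500 nM, within the range 500 nM to 4500 nM.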

Compound 4, half-maximal inhibitory concentration: 830 nM
Compound 4: the middle estimate sits 1.8-fold (0.26 log units) above what was measured; low and high end bracket the measured number.
By their numbers in this assay, from the lowest: compound 2; then compounds 4, 3 and 1 (each within the scatter of the next, the first and the last beyond it).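

In this assay, the measured step is a 2.0-fold lower number from compound 1 to compound 4 (0.31 log units; beyond the scatter) and shows that carboxymethoxy is accepted in place of carboxy on this saturated ring carbon, with a modest gain rather than a loss. For the compounds shown here, this is the first step between close neighbours at the acid end, as the earlier step changed only a group on an aromatic carbon. Nothing available explains this gain.

Going by these compounds, whether a longer chain ending in the acid would extend the gain remains open, as does the effect of an amine or a tetrazole here. Also open, on these data alone, is whether carboxymethoxy would give a similar step on compound 2.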